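Swapping a Ring Amine for an Open-Chain Amine

The compounds below may be only part of what the source reports. "The series", "measured", "known", "first", "only" and "open" are said of these compounds alone.

Measured so far:
compound 1, `O=C(CN1CCCCC1)NCCNc1ccnc2cc(Cl)ccc12`: 23700 nM
compound 2, `CN1CCN(CCNc2ccnc3cc(Cl)ccc23)CC1`: 16700 nM
compound 3, `Clc1ccc2c(NCCCN3CCCCCC3)ccnc2c1`: 20000 nM

All three compounds carry the shared core and differ only in the side chain attached to it. They were tested in a toxicity assay (L6 cells) for inhibition, with Rattus norvegicus as the target, read by resazurin assay, with a stated time of 70 h; a higher number here means a weaker inhibitor, a lower number a stronger inhibitor. In this assay compound 2 gives 16700 nM, compound 3 gives 20000 nM and compound 1 gives 23700 nM. Compound 2 has the smallest of the three numbers, but its gaps to compound 3 and to compound 1 both fall within the usual scatter of repeat measurements, so the three cannot be told apart on these data.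

Compound 4, `CCCN(CCC)CCNc1ccnc2cc(Cl)ccc12`, has not yet been measured. It differs from compound 2 in one place: dipropylamino in place of 4-methylpiperazin-1-yl on a saturated chain carbon, two bonds along the chain from a nitrogen on an aromatic ring. Going by the values given here, no pair of measured compounds that differ in a single place is available to calibrate this change, so the expectation rests on the flat picture above.

The step of a 1.2-fold higher number from compound 2 to compound 4 (0.08 log units; within the scatter) is expected to be small, with no clear direction beyond the scatter. Compound 4 is therefore estimated at 20000 nM, with a range from 8000 nM to 50000 nM.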

Compound 4, half-maximal inhibitory concentration: 14900 nM
The estimate for compound 4 lay 1.3-fold (0.13 log units) above the measured number; the measured number falls inside the stated range.
By their numbers in this assay, from the lowest: compounds 4, 2, 3 and 1 (each within the scatter of the next).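

In this assay, putting dipropylamino in place of 4-methylpiperazin-1-yl gives a 1.1-fold lower number from compound 2 to compound 4 (0.05 log units; within the scatter). Going by these compounds alone, this is the first comparison here between compounds that differ in one place, and it shows that, on a saturated chain carbon two bonds along the chain from a nitrogen on an aromatic ring, exchanging a ring amine for an open-chain amine does not shift the number beyond the scatter. No other measurement bears on this result, so the flat step stays unexplained.

The compounds shown leave open whether a carboxylic acid or a morpholine ring at this place would also leave the number within the scatter. They also leave open whether dipropylamino on a longer chain would behave the same way.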